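Coumarin thioester to anilide: migration read-out

The source may hold more compounds than are shown below. What is called first, only, known or untested is meant among the compounds shown, and "the series" means these compounds.

Measured compounds in a functional assay on HT-1080 cells (Homo sapiens), read by transwell migration, with a stated time of 24 h, tested at 0.1 uM; a higher number here means a weaker effect of the compound at the concentration tested, a lower number a stronger effect:
Compound 1, `CC(=O)OCc1ccc2oc(=O)c(C(=O)Sc3ccccc3)cc2c1`, gives 89.5%.
Compound 2, `CC(=O)OCc1ccc2oc(=O)c(C(=O)Sc3cccc(Cl)c3)cc2c1`, gives 76.5%.

Within this pair, compound 2 stands lowest; its nearest neighbour is compound 1, and the step of a number 13 percentage points lower from compound 1 to compound 2 (beyond the scatter) is the only measured step in the set. It concerns a chloro in place of hydrogen on an aromatic carbon and says nothing about the carbonyl substituent.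

Compound 3, `CC(=O)OCc1ccc2oc(=O)c(C(=O)Nc3cccc(Cl)c3)cc2c1`, is not yet measured in this assay. It differs from compound 2 by (3-chlorophenyl)amino in place of (3-chlorophenyl)sulfanyl on a carbonyl carbon. No measured step touches this position or exchanges a sulfanyl for an amino group, so the direction and size of the change are not anchored by any shown pair. Within the data shown here, the one step available, the chloro step from compound 1 to compound 2, is retained unchanged in compound 3 and gives no guidance here.

With nothing comparable to lean on, the expectation for compound 3 is placed near the measured pair rather than outside it, and the estimated step of a number 3.5 percentage points higher from compound 2 to compound 3 (within the scatter) is taken as small and uncertain in sign. Compound 3 is therefore estimated at 80%, with a range from 55% to 100%.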

Compound 3, a percentage reported as activity, at one concentration (the size of the read-out at that concentration, not a potency): 79.6%
Beside the measured number, compound 3's estimate is 0.4 percentage points above it; the range from low to high includes it.
By their numbers in this assay, from the lowest: compounds 2, 3 and 1 (each within the scatter of the next, the first and the last beyond it).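

In this assay, among these compounds, the first change at the carbonyl substituent gives a number 3.1 percentage points higher from compound 2 to compound 3 (within the scatter), so replacing (3-chlorophenyl)sulfanyl with (3-chlorophenyl)amino on this carbonyl carbon does not separate the two compounds, even though a hydrogen-bond donor enters and a hydrogen-bond acceptor leaves. The comparison with the unchlorinated thioester gives a number 9.9 percentage points lower from compound 1 to compound 3 (within the scatter), whereas the earlier step gave a number 13 percentage points lower from compound 1 to compound 2 (beyond the scatter), so only compound 2 is clearly separated from compound 1, and compound 3 is separated from neither of the other two. No available evidence bears on why the sulfanyl-to-amino exchange leaves the read-out within the scatter.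

Phenylamino, the anilide without chloro, would show whether the chloro step seen between the thioesters carries over to the amino series. An oxygen link as in a phenyl ester, a benzylamino group on the same carbonyl carbon, or a free hydroxymethyl in place of the acetoxymethyl group remains open, as does the behaviour of any of these compounds at other concentrations.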